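Nitro in Place of Trifluoromethyl on a Shared Core

The compounds below may be only part of what the source reports. "The series", "measured", "known", "first", "only" and "open" are said of these compounds alone.

Measured compounds:
compound 1, `CC(C)=CCC/C(C)=C/CC1Cc2c(O)cc(=O)n(CCCO)c2CC1(C)C`, 0%
compound 2, `CC(C)=CCC1Cc2c(OCCCNS(=O)(=O)c3ccc(C(F)(F)F)cc3)cc(=O)n(CCCO)c2CC1(C)C`, 0%

In a functional assay on PANC-1 cells (Homo sapiens) for inhibition, read by MTT assay, with a stated time of 24 h, tested at 10 uM (a lower number here means less inhibition, a higher number more inhibition at the concentration tested (going by the name of the read-out)), compound 1 gives 0%. Compound 2 keeps the same core but replaces the free hydroxyl with a longer side chain ending in an aromatic ring that carries a trifluoromethyl group. In this assay compound 2 gives 0%, level with compound 1 at the digits printed, so the two values show no difference beyond the usual scatter of such measurements.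

Compound 3 `CC(C)=CCC1Cc2c(OCCCNS(=O)(=O)c3ccc([N+](=O)[O-])cc3)cc(=O)n(CCCO)c2CC1(C)C` is the next compound to be examined. It differs from compound 2 in a single place: nitro in place of trifluoromethyl on an aromatic carbon.

Among the measured compounds shown here, no measured pair shows this particular change, so there is no step to lean on. Both measured compounds sit at the floor of the read-out, and a single exchange at the far end of the side chain is not expected to move the number beyond the scatter; the expected step is a number 3 percentage points higher from compound 2 to compound 3 (within the scatter). Compound 3 is therefore estimated to give 3% in this assay, with a range from 0% to 15%.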

Compound 3, a percentage reported as inhibition, at one concentration (the size of the read-out at that concentration, not a potency): 17.3%
The estimate for compound 3 lay 14.3 percentage points below the measured number; measured number outside the range, above it.
By their numbers in this assay, from the lowest: compounds 1 and 2 (each within the scatter of the next); then compound 3.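

In this assay the two earlier compounds sat level at the bottom of the read-out, so they gave no sign that any part of the side chain could shift the number. The exchange of trifluoromethyl for nitro, on an aromatic carbon para to a large group, gives a number 17.3 percentage points higher from compound 2 to compound 3 (beyond the scatter) and so shows that this far end of the side chain is not silent: changing 4-(trifluoromethyl)phenyl to 4-nitrophenyl, with the rest of the molecule untouched, is enough to lift the result off the floor. Nothing measured here speaks to why this exchange has that effect.

The compounds shown leave open whether the rise belongs to nitro alone or would also appear with another group at the same carbon, such as an amine, a nitrile or a carboxylic acid. They also leave open how the inhibition of compound 3 would change across other concentrations, since a reading at one concentration is not a potency.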